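A few compounds are considered here, and "the series" means these few. Any claim that something is new, unique, unknown or untested is made for them only; others in the source may bear on it.

Working notes on the series, read in a functional assay on HEK293 cells (Homo sapiens) for cytotoxicity; on this read-out lower numbers stand for higher toxicity in this test and higher numbers for lower toxicity in this test. Compound 1 `COc1ccc([C@H]2CC(=O)N(c3ccncc3)C2)cc1OC1CCCC1` gives > 10000 nM, which is a limit of the assay. Compound 2 `COc1ccc([C@H]2CC(=O)N(c3cccc(S(C)(=O)=O)c3)C2)cc1OC1CCCC1` gives > 10000 nM, again a limit and not a number. Among the measured compounds shown here, the only measured change is a step that the two limits leave unreadable from compound 1 to compound 2, with 3-(methylsulfonyl)phenyl in place of pyridin-4-yl on an amide-type nitrogen in a ring. Both compounds stand at the same bound: the limit of > 10000 nM in this assay, at which 2 of the 2 values shown sit.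

Compound 3 `COc1ccc([C@H]2CC(=O)N(c3ccc(S(C)(=O)=O)cc3)C2)cc1OC1CCCC1` keeps the atoms of compound 2, joined differently: 4-(methylsulfonyl)phenyl in place of 3-(methylsulfonyl)phenyl on an amide-type nitrogen in a ring. 4-(methylsulfonyl)phenyl takes the place of 3-(methylsulfonyl)phenyl on the same nitrogen.

For the measured compounds named here, no measured step of readable size bears on this change, so no shift beyond the scatter is expected in this assay, and no direction is favoured. The expected step is a step that the limit leaves unreadable from compound 2 to compound 3. For compound 3 the estimated value is 12000 nM, with an expected range of 6000 nM to 30000 nM.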

Compound 3, half-maximal cytotoxic concentration: > 10000 nM
Compound 3 was reported as a limit; the forecaster's own chance of this, stated with the estimate: 85%; the middle value does not contradict the limit.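

No new step can be read, since compound 3, like compound 1 and compound 2, is reported only as a limit: the limit of > 10000 nM in this assay, at which 3 of the 3 values shown sit.

The compounds shown leave open how far apart compound 1, compound 2 and compound 3 lie in this assay, and whether any change on the amide-type nitrogen gives a readable value.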